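Swapping the hydroxyphenyl for a chlorophenyl on the fused core

A few compounds are considered here, and "the series" means these few. Any claim that something is new, unique, unknown or untested is made for them only; others in the source may bear on it.

Compound 1, `C=CCc1cc(O)cc2c1OC(c1ccc(O)cc1)CC2=O`, gives 95.3% in a functional assay on aorta (Rattus norvegicus, strain Sprague-Dawley) for inhibition, with a stated time of 20 min; a lower number here means a smaller maximal response, a higher number a larger maximal response.
Compound 2, `C=CCc1cc(O)cc2c1OC(c1cccc(O)c1)CC2=O`, gives 90.2% in this assay.

Within the data shown here, of the two compounds measured so far, compound 2 stands at the lower of the two numbers, with compound 1 the only neighbour; the step of a number 5.1 percentage points lower from compound 1 to compound 2 (within the scatter) lies within the scatter, so the two are not separated by this read-out.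

The next compound, compound 3, `C=CCc1cc(O)cc2c1OC(c1ccc(Cl)cc1)CC2=O`, differs from compound 2 in one place: 4-chlorophenyl in place of 3-hydroxyphenyl on a saturated ring carbon.

Among the measured compounds shown here, only one measured step bears on this change, and only in part. The step of a number 5.1 percentage points lower from compound 1 to compound 2 (within the scatter) shows that moving the hydroxyl around the aromatic ring on the saturated ring carbon changes nothing beyond the scatter. For the measured compounds named here, no measured pair shows what happens when the hydroxyl leaves altogether or when chlorine enters, so the larger part of the change is untested. Going by the values given here, with the one relevant step flat, the expectation is a small step, and the estimated step of a number 2.2 percentage points lower from compound 2 to compound 3 (within the scatter) is expected to stay within the scatter. Compound 3 is therefore estimated at about 88%, with a range from 70% to 100%.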

Compound 3, largest response reached (Emax), in percent of the reference or control that the assay uses: 95.1%
Compound 3: middle estimate off by 7.1 percentage points, on the low side; the measured number falls inside the stated range.
By their numbers in this assay, from the lowest: compounds 2, 3 and 1 (each within the scatter of the next).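

In this assay, the full exchange of 3-hydroxyphenyl for 4-chlorophenyl on the saturated ring carbon next to the ring oxygen gives a number 4.9 percentage points higher from compound 2 to compound 3 (within the scatter) and so goes further than the earlier shift of the hydroxyl around the aromatic ring: here the hydroxyl leaves altogether and chlorine enters, and the read-out still does not separate the two compounds. The more direct comparison, chloro in place of hydroxy on an aromatic carbon, gives a number 0.2 percentage points lower from compound 1 to compound 3 (within the scatter) and shows that this single replacement, which takes away the hydrogen-bond donor and acceptor counted on the hydroxyphenyl group, also leaves the maximal response within the scatter. Nothing available accounts for this flat outcome.

All three aromatic groups at this carbon thus fall within the scatter of one another, so the compounds shown do not reveal any group at this place that changes the maximal response. As far as these compounds go, it remains open whether an aminophenyl or a carboxyphenyl group on the saturated ring carbon, or a longer chain there in place of the aromatic ring, would move the read-out beyond the scatter.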